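Chloro to Bromo: Cytotoxicity Step on an Oxime Scaffold

A few compounds are considered here, and "the series" means these few. Any claim that something is new, unique, unknown or untested is made for them only; others in the source may bear on it.

Measured so far:
- compound 1, `COc1ccc(C(/C=C/c2ccc(Br)cc2)=N/O)cc1`, 737000 nM
- compound 2, `Cc1ccc(C(/C=C/c2ccc(Cl)cc2)=N/O)cc1`, 21300 nM

Of the compounds shown here, two have been tested in an ADME assay on cells (Mus musculus, strain Balb/c) for cytotoxicity, read by MTT assay, with a stated time of 48 h; a lower number here means that less compound is tolerated, a higher number that more compound is tolerated. Compound 2 gives 21300 nM, the lowest of the two numbers, meaning it is the one tolerated at the lower concentration. Compound 1 gives 737000 nM, a far higher number, a gap well beyond the scatter; the two structures differ in more than one place, so that gap is not tied to any single change.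

Compound 3, `Cc1ccc(C(/C=C/c2ccc(Br)cc2)=N/O)cc1`, has not yet been measured. It differs from compound 2 by a single exchange: bromo in place of chloro on an aromatic carbon. For the measured compounds named here, no single step of this kind between measured compounds is available, so the effect in this assay can only be expected, not read off. A halogen swap of this sort is anticipated to shift the number only a little, likely within the scatter, perhaps leaning toward a higher value. Compound 3 is therefore estimated at 30000 nM, within 10000 nM to 100000 nM, an expected step of a 1.4-fold higher number from compound 2 to compound 3 (0.15 log units; within the scatter).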

Compound 3, half-maximal cytotoxic concentration: 34200 nM
Beside the measured number, compound 3's estimate is 1.1-fold (0.06 log units) below it; low and high end bracket the measured number.
By their numbers in this assay, from the lowest: compounds 2 and 3 (each within the scatter of the next); then compound 1.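

In this assay, bromo in place of chloro on an aromatic carbon, para to a large group, gives a 1.6-fold higher number from compound 2 to compound 3 (0.21 log units; within the scatter), so at this position the two halogens cannot be told apart. For the compounds shown here, by contrast, methyl in place of methoxy on an aromatic carbon gives a 22-fold lower number from compound 1 to compound 3 (1.33 log units; beyond the scatter), which shows that of these two single exchanges, only this one moves the number beyond the scatter. No evidence is available to explain why one exchange moves the number and the other does not.

From the compounds shown here alone, the halogen position is described by chloro and bromo alone, so it remains open whether fluoro, an amine or a carboxylic acid there would also leave the number unchanged. At the methoxy position, the compounds shown do not tell how a hydroxyl or a longer chain such as ethoxy would read.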